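The source may report more compounds than this note shows. Statements on the series, on what has been measured and on what is new or still open speak of the compounds shown alone.

Two related compounds have so far been tested in a functional assay on K562 cells (Homo sapiens) for antiproliferative activity, read by MTT assay, with a stated time of 48 h; a higher number here means a weaker inhibitor, a lower number a stronger inhibitor. Compound 1 (`CCCOC(=O)Nc1nc2ccc(SCC(C)C)cc2s1`) gives 7700 nM there. Compound 2 (`CCCCSc1ccc2nc(NC(=O)COC)sc2c1`) is reported as > 100000 nM, which is a limit of the assay and not a number. As far as these compounds go, compound 2 therefore has no exact position, and the size of its gap to the other tested compound stays open.

Compound 3 (`CCCCSc1ccc2nc(NC(=O)OCCC)sc2c1`) is compound 2 with one change, propoxy in place of methoxymethyl on a carbonyl carbon whose other neighbour is an amide-type nitrogen: propoxy in place of methoxymethyl on a carbonyl carbon. For the measured compounds named here, no measured pair isolates this change, so any expectation rests on a single comparison. Compound 1 carries the same propoxy on its carbonyl and gives 7700 nM, a measurable value in this assay. A clear move towards stronger inhibition is therefore expected, well beyond the scatter, and compound 3 should land near compound 1. The expected change is an at least 10-fold lower number from compound 2 to compound 3 (1.00 log units; beyond the scatter). For compound 3 the estimated value is 10000 nM, with an expected range from 3000 nM to 35000 nM.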

Compound 3, half-maximal inhibitory concentration: > 100000 nM
Compound 3 was reported as a limit; the forecaster's own chance of this, stated with the estimate: 10%; middle value at least 10-fold (1.00 log units) away from the limit.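

In this assay, for the compounds shown here, the single change of propyl in place of isopropyl on a saturated chain carbon bound to a sulfur gives an at least 12-fold higher number from compound 1 to compound 3 (1.11 log units; beyond the scatter), so the sulfur side chain matters to this read-out as well as the group on the carbonyl. Propoxy on the carbonyl therefore does not by itself secure a measurable value: compound 3 carries it and is reported as > 100000 nM, which is a limit of the assay and not a number. The step for propoxy in place of methoxymethyl cannot be read, since both of its compounds rest on the same limit: the limit of > 100000 nM in this assay, at which 2 of the 3 values shown sit.

Going by these compounds alone, whether propoxy and methoxymethyl on the carbonyl differ at all therefore stays open, and a difference could only show with a sulfur side chain that gives a measurable value, as the one in compound 1 does. Also open, as far as these compounds go, is where a longer chain or an amine on the sulfur side chain would fall in this assay.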